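Swapping a difluorophenoxy ring for a chlorophenoxy ring

The source may hold more compounds than are shown below. What is called first, only, known or untested is meant among the compounds shown, and "the series" means these compounds.

Compound 1 `Cc1nn(C)c(Oc2ccccc2F)c1/C=N\CCCCCCOc1cc2oc(=O)cc(C)c2cc1Cl` gives > 25000 nM in a functional assay on HepG2 cells (Homo sapiens) for antiproliferative activity, read by MTT assay, with a stated time of 72 h (on this read-out lower numbers stand for stronger inhibition and higher numbers for weaker inhibition), which is a limit of the assay rather than a number.
Compound 2 `Cc1nn(C)c(Oc2ccc(F)cc2)c1/C=N\CCCCCCOc1cc2oc(=O)cc(C)c2cc1Cl` gives 12500 nM in this assay.
Compound 3 `Cc1nn(C)c(Oc2ccc(F)c(F)c2)c1/C=N\CCCCCCOc1cc2oc(=O)cc(C)c2cc1Cl` gives > 25000 nM in this assay, again a limit of the assay.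

Compound 3 therefore stands at the weak end of what was measured, with only a limit. Two of the three values sit at that same point, as the limit of > 25000 nM in this assay, at which 2 of the 3 values shown sit, shows. The measured steps all concern the fluorine pattern on the phenoxy ring: an at least 2.0-fold lower number from compound 1 to compound 2 (0.30 log units; that floor lies within the scatter), an at least 2.0-fold higher number from compound 2 to compound 3 (0.30 log units; that floor lies within the scatter), and a step that the two limits leave unreadable from compound 1 to compound 3. None of them rises clearly above the scatter, so the fluorine pattern on this ring barely moves the number.

Compound 4 `Cc1nn(C)c(Oc2cccc(Cl)c2)c1/C=N\CCCCCCOc1cc2oc(=O)cc(C)c2cc1Cl` is not yet measured. It differs from compound 3 in one place: 3-chlorophenyl in place of 3,4-difluorophenyl on an oxygen on an aromatic ring. Within the data shown here, no measured step exchanges fluorine for chlorine on this ring, so the nearest guide is the small movement seen across compounds 1, 2 and 3. The step of an at least 1.2-fold lower number from compound 3 to compound 4 (0.09 log units; that floor lies within the scatter) is thus expected to stay within the scatter. Compound 4 is estimated at 20000 nM in this assay, with a range from 8000 nM to 50000 nM, and a fair chance that only a limit is reported.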

Compound 4, half-maximal inhibitory concentration: 6220 nM
The estimate for compound 4 lay 3.2-fold (0.51 log units) above the measured number; the measured number lies below the stated range.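

Among the rings on this oxygen, the 3-chlorophenyl group gives the first steps that clear the scatter in this assay, with an at least 4.0-fold lower number from compound 3 to compound 4 (0.60 log units; beyond the scatter) and an at least 4.0-fold lower number from compound 1 to compound 4 (0.60 log units; beyond the scatter), so this position can move the number more than the fluorine patterns alone had shown. The change does not separate compound 4 from every earlier compound, however, as the comparison with the 4-fluorophenyl ring gives a 2.0-fold lower number from compound 2 to compound 4 (0.30 log units; within the scatter), which leaves those two compounds indistinguishable in this test. Both clear steps are only minimum sizes, because compound 1 and compound 3 each carry a limit of the assay rather than a number: the limit of > 25000 nM in this assay, at which 2 of the 4 values shown sit.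

The 3-chlorophenyl ring differs from the fluorinated rings in both the halogen and its place, so the compounds shown cannot say which of the two matters, and a 3-fluorophenyl or 4-chlorophenyl ring would be needed to pull them apart. They also leave open whether a 3-bromophenyl or 3-methoxyphenyl ring would hold or extend this gain, and whether a longer chain would change the picture.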